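The source may hold more compounds than are shown below. What is called first, only, known or untested is meant among the compounds shown, and "the series" means these compounds.

Of the compounds shown here, three have been measured so far, all sharing one core and differing only in the group on the amide carbonyl carbon. Compound 1 `CC(C)CCC(=O)N[C@@H](C(=O)N1CCC(c2ccc(Cl)cc2)CC1)C(C)C` carries an isopentyl there and in an assay on THP-1 cells for displacement of a labelled ligand from C-C chemokine receptor type 1 (Homo sapiens) (a higher number here means a weaker inhibitor, a lower number a stronger inhibitor), compound 1 gives 26 nM. Compound 2 `CC(C)[C@@H](NC(=O)c1nc2ccccc2s1)C(=O)N1CCC(c2ccc(Cl)cc2)CC1` carries a 1,3-benzothiazol-2-yl, and in this assay compound 2 gives 18 nM. Compound 3 `CC(C)[C@@H](NC(=O)c1ccc(F)c(F)c1)C(=O)N1CCC(c2ccc(Cl)cc2)CC1` carries a 3,4-difluorophenyl, and in this assay compound 3 gives 14 nM, the lowest of the three numbers, though the steps to it are small: a 1.9-fold lower number from compound 1 to compound 3 (0.27 log units; within the scatter) and a 1.3-fold lower number from compound 2 to compound 3 (0.11 log units; within the scatter), and likewise a 1.4-fold lower number from compound 1 to compound 2 (0.16 log units; within the scatter). None of these three changes at the carbonyl carbon moved the number beyond the scatter.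

Compound 4 `CC(C)[C@@H](NC(=O)CCCc1ccccc1)C(=O)N1CCC(c2ccc(Cl)cc2)CC1` is not yet measured. It differs from compound 3 in one place: 3-phenylpropyl in place of 3,4-difluorophenyl on a carbonyl carbon. The step from compound 1 to compound 3, which swapped a flexible chain for an aromatic ring, bears most directly on this change, and it was within the scatter. Among the measured compounds shown here, since every change at this position so far stayed within the scatter, compound 4 is expected to show a step of about a 1.8-fold higher number from compound 3 to compound 4 (0.25 log units; within the scatter), with its number in this assay estimated at 25 nM, likely between 10 nM and 60 nM.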

Compound 4, half-maximal inhibitory concentration: 95 nM
Compound 4: the middle estimate sits 3.8-fold (0.58 log units) below what was measured; measured number outside the range, above it.
By their numbers in this assay, from the lowest: compounds 3, 2 and 1 (each within the scatter of the next); then compound 4.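

Among the compounds shown here, this position tolerates less than the earlier compounds suggested: in this assay, 3-phenylpropyl gives the first steps here that lie beyond the scatter, a 6.8-fold higher number from compound 3 to compound 4 (0.83 log units; beyond the scatter) and a 5.3-fold higher number from compound 2 to compound 4 (0.72 log units; beyond the scatter). Having an aromatic ring is not enough to keep the number low, as 3,4-difluorophenyl and 3-phenylpropyl each carry one six-membered aromatic ring of carbon only. Compared with the chain of compound 1, benzyl in place of isopropyl on a saturated chain carbon also raises the number, a 3.7-fold higher number from compound 1 to compound 4 (0.56 log units; beyond the scatter), and nothing available here explains these steps.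

From the compounds shown here alone, it remains open whether a shorter link, as in 2-phenylethyl or benzyl on the carbonyl carbon, would give a number nearer that of compound 3 or that of compound 4. Also open, going by these compounds, is how a chain holding an amine or a carboxylic acid would behave in this assay.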